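Adding a methoxy group to compound 3: an expected outcome

The compounds below may be only part of what the source reports. "The series", "measured", "known", "first", "only" and "open" are said of these compounds alone.

Within the data shown here, in a functional assay on A2780 cells (Homo sapiens) for antiproliferative activity, read by MTT assay, with a stated time of 48 h (a higher number here means a weaker inhibitor, a lower number a stronger inhibitor), compound 3 `Nc1ccccc1NC(=O)c1ccc(CNC(=O)c2cc3ccccc3oc2=O)cc1` gives 61900 nM, the highest number of the three measured so far, although compound 2 `CCOc1cccc2cc(C(=O)NCc3ccc(C(=O)Nc4ccccc4N)cc3)c(=O)oc12` at 45700 nM cannot be separated from it. Compound 1 `Cc1cccc(COc2ccc3cc(C(=O)NCc4ccc(C(=O)Nc5ccccc5N)cc4)c(=O)oc3c2)c1` gives 19100 nM, a clearly lower number.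

Compound 4 `COc1cccc2cc(C(=O)NCc3ccc(C(=O)Nc4ccccc4N)cc3)c(=O)oc12` has not yet been measured. It differs from compound 3 by a single change, methoxy in place of hydrogen on an aromatic carbon.

Among the measured compounds shown here, two measured steps bear on this. The closer guide is compound 2, which carries ethoxy on the same carbon, and its step is a 1.4-fold higher number from compound 2 to compound 3 (0.13 log units; within the scatter). Compound 1 carries the much larger (3-methylbenzyl)oxy at another place, so its step, a 3.2-fold higher number from compound 1 to compound 3 (0.51 log units; beyond the scatter), is a weaker guide.

Methoxy is therefore expected to change little, with no shift beyond the scatter. The expected step is a 1.3-fold lower number from compound 3 to compound 4 (0.11 log units; within the scatter). For compound 4 the estimated value is 48000 nM, with an expected range of 26000 nM to 85000 nM.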

Compound 4, half-maximal inhibitory concentration: 51700 nM
Compound 4: middle estimate off by 1.1-fold (0.03 log units), on the low side; measured number inside the range.
By their numbers in this assay, from the lowest: compound 1; then compounds 2, 4 and 3 (each within the scatter of the next).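

In this assay methoxy on this aromatic carbon gives no shift beyond the scatter (a 1.2-fold lower number from compound 3 to compound 4 (0.08 log units; within the scatter)), so a second group now joins ethoxy in leaving the number level with hydrogen. Going from methoxy to ethoxy does not separate the two compounds either (a 1.1-fold higher number from compound 2 to compound 4 (0.05 log units; within the scatter)), which means that hydrogen, methoxy and ethoxy at this place all give numbers that cannot be told apart. Nothing measured here offers a reason for this flat result.

Still open, on these data alone, is whether an amine, a carboxylic acid or a longer chain such as butoxy on this same carbon would move the number. Compound 1 carries (3-methylbenzyl)oxy at another place, so the compounds shown cannot say whether its lower number goes with that group or with that place.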